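The source may hold more compounds than are shown below. What is called first, only, known or untested is meant among the compounds shown, and "the series" means these compounds.

Measured so far:
compound 1 `COc1cccc(/C=C2\CCC/C(=C\c3cccc(OC)c3OC)C2=O)c1`: 5900 nM
compound 2 `COc1ccc(/C=C2\CCC/C(=C\c3ccc(Br)cc3)C2=O)cc1OC`: 6900 nM

Both values come from a functional assay on MCF7 cells (Homo sapiens) for cytotoxicity, read by MTT assay, with a stated time of 72 h; on this read-out lower numbers stand for stronger inhibition and higher numbers for weaker inhibition. Among the measured compounds shown here, compound 2 stands level with the only other measured compound: its value and that of compound 1 lie within the usual scatter of each other, so the numbers separate neither of them. For the measured compounds named here, these two compounds differ in more than one place, and no measured pair differs in one place only, so the data hold no direct measure of a single change.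

The next compound, compound 3 `COc1ccc(/C=C2\CCC/C(=C\c3ccc(Cl)c(Cl)c3)C2=O)cc1OC`, carries 3,4-dichlorophenyl in place of 4-bromophenyl on a double-bonded chain carbon bound to a double-bonded ring carbon. No step beyond the scatter is expected in this assay, and neither direction is favoured. This expectation rests on compound 2 at 6900 nM and compound 1 at 5900 nM, which stay close despite differing in more than one place. The expected step of a 1.3-fold lower number from compound 2 to compound 3 (0.10 log units; within the scatter) is therefore small. For compound 3 the estimated value is 5500 nM, with an expected range of 2200 nM to 13000 nM.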

Compound 3, half-maximal inhibitory concentration: 4400 nM
Compound 3: middle estimate off by 1.3-fold (0.10 log units), on the high side; the range from low to high includes it.
By their numbers in this assay, from the lowest: compounds 3, 1 and 2 (each within the scatter of the next).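

In this assay, among the compounds shown here, the first comparison that isolates one place is a 1.6-fold lower number from compound 2 to compound 3 (0.20 log units; within the scatter). At a double-bonded chain carbon bound to a double-bonded ring carbon, 3,4-dichlorophenyl and 4-bromophenyl therefore cannot be told apart, whereas the closeness of compound 1 and compound 2 could not be assigned to any one place. The exchange alters both the halogen and the number of halogen atoms on the phenyl ring, and this single step does not separate those two parts of the change. No supporting data on either group accompany this result, and the step stands without an explanation.

Still open, as far as these compounds go, is whether this position stays as flat for groups other than halogenated phenyl, for example a phenyl carrying a dimethylamino group or a carboxylic acid, either of which could test whether the value moves beyond the scatter. The contribution of the dimethoxyphenyl group shared by compound 2 and compound 3 also remains open, as the compounds shown give no step for a change at that end of the shared core.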